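A tert-butyl group on the piperazine of compound 2

The compounds below may be only part of what the source reports. "The series", "measured", "known", "first", "only" and "open" are said of these compounds alone.

- compound 1 `CN1CCN(C2CCN(c3nccc4[nH]c(-c5ccc(F)c(F)c5)nc34)CC2)CC1` gives 130000 nM
- compound 2 `Fc1cc(F)cc(-c2nc3c(N4CCC(CN5CCNCC5)CC4)nccc3[nH]2)c1` gives 190000 nM

In a physicochemical assay for solubility, read by HPLC, using the shake flask method, in phosphate buffer, with a stated time of 20 h, at pH 6.5 (a higher number here means a more soluble compound, a lower number a less soluble compound), compound 2 stands at 190000 nM and compound 1 at 130000 nM so the two lie within the usual scatter of repeated measurements and cannot be ranked. Within the data shown here, they also differ in more than one place, so no measured pair here shows what a single change does.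

Compound 3 `CC(C)(C)N1CCN(CC2CCN(c3nccc4[nH]c(-c5cc(F)cc(F)c5)nc34)CC2)CC1` offers such a single change. It is compound 2 with tert-butyl in place of hydrogen on an amine nitrogen in a ring, which turns piperazin-1-yl into 4-(tert-butyl)piperazin-1-yl. Compound 1 at 130000 nM also carries a group on an amine nitrogen in a ring, so a collapse in this assay is not expected, only a modest fall that may just clear the scatter. Among the measured compounds shown here, the expected move is a 2.4-fold lower number from compound 2 to compound 3 (0.38 log units; beyond the scatter) and it remains a judgement, since no measured pair tests it. Compound 3 is estimated at 80000 nM with 20000 nM to 200000 nM as the expected range.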

Compound 3, solubility: 185000 nM
Beside the measured number, compound 3's estimate is 2.3-fold (0.36 log units) below it; the range from low to high includes it.
By their numbers in this assay, from the lowest: compounds 1, 3 and 2 (each within the scatter of the next).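

In this assay, putting tert-butyl in place of hydrogen on the amine nitrogen in the ring gives a 1.0-fold lower number from compound 2 to compound 3 (0.01 log units; within the scatter), so compound 2 and compound 3 cannot be told apart. Among these compounds, this is the first single change that can be read in this set, and it shows that, in this pair, the hydrogen on that nitrogen can give way to tert-butyl with no difference beyond the scatter. The comparison holds only for piperazin-1-yl against 4-(tert-butyl)piperazin-1-yl on this scaffold, and no measurement shown here offers an explanation for the result.

Going by these compounds, whether the same holds for other groups on this nitrogen remains open, for example an acetyl group, which would turn the amine into an amide, or a short chain ending in a carboxylic acid. Compound 1 cannot settle this, since it differs from compound 2 in more than one place, so the effect of the methyl group it carries on a ring nitrogen cannot be separated from its other differences.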